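The compounds below may be only part of what the source reports. "The series", "measured", "known", "first", "only" and "open" are said of these compounds alone.

Working notes on the series. Compound 1 `COC(=O)C1=C(C)NC(C)=C(C(=O)OC)C1c1cccc(OCC(=O)N2CCN(C)CC2)c1`, compound 2 `COC(=O)C1=C(C)NC(C)=C(C(=O)OC)C1c1ccc(OCC(=O)n2ccnc2)c(OC)c1` and compound 3 `COC(=O)C1=C(C)NC(C)=C(C(=O)OC)C1c1cccc(OCC(=O)N2CCCCC2)c1` share one core and differ in the group attached to a carbonyl carbon of the side chain and in the substitution of the aryl ring. In an assay on cells for inhibition of Voltage-gated L-type calcium channel (Rattus norvegicus), read by fluorescence and calcium flux, with stated times of 30 min and 2 min (on this read-out lower numbers stand for stronger inhibition and higher numbers for weaker inhibition), compound 1 gives 10000 nM, compound 3 gives 10000 nM and compound 2 gives 10100 nM. Compound 2 carries the nominally top figure of the three, but its gaps to compound 1 and to compound 3 both lie within the scatter, so the three sit at one level. Within the data shown here, the only measured single-point step, no change at the digits printed from compound 1 to compound 3 (within the scatter), likewise shows that exchanging the amine on the carbonyl carbon leaves the number where it was.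

Compound 4 `COC(=O)C1=C(C)NC(C)=C(C(=O)OC)C1c1ccc(OCC(=O)N2CCN(C)CC2)c(OC)c1` has not yet been measured in this assay. Its change from compound 2 is 4-methylpiperazin-1-yl in place of 1H-imidazol-1-yl on a carbonyl carbon. Among the measured compounds shown here, the step from compound 1 to compound 3 is the one measured comparison of amine groups on that carbonyl carbon, and it was flat; compound 1, which already carries the entering 4-methylpiperazin-1-yl, gives 10000 nM. No change beyond the scatter is therefore expected, with a 1.0-fold lower number from compound 2 to compound 4 (0.00 log units; within the scatter) as the estimated step. Compound 4 is expected to give 10000 nM in this assay, between 5000 nM and 20000 nM.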

Compound 4, half-maximal inhibitory concentration: 9100 nM
For compound 4 the middle estimate is 1.1-fold (0.04 log units) above the measured one; the measured number falls inside the stated range.
By their numbers in this assay, from the lowest: compounds 4, 1, 3 and 2 (each within the scatter of the next).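

In this assay, the exchange on the carbonyl carbon gives a 1.1-fold lower number from compound 2 to compound 4 (0.05 log units; within the scatter), so the two compounds sit at one level. The earlier step on this carbonyl carbon joined two six-membered non-aromatic rings, whereas this one replaces a five-membered aromatic ring, 1H-imidazol-1-yl, with a six-membered non-aromatic ring, 4-methylpiperazin-1-yl, and goes from 2 hydrogen-bond acceptors to 1. The flat reading at this position therefore now spans a difference in ring size, in aromaticity and in acceptor count, and it also holds on the aryl substitution of compound 2 and compound 4, although no evidence on hand accounts for it.

Going by these compounds, all the groups compared on this carbonyl carbon are ring amines or an imidazole, so it remains open whether an open-chain amine such as dimethylamino, or a hydroxyl group that would make the side chain a carboxylic acid, would shift the number beyond the scatter. Also open, on these data alone, is whether a longer chain between the ether oxygen and the carbonyl would leave the number at this same level.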